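The source may report more compounds than this note shows. Statements on the series, on what has been measured and on what is new or still open speak of the compounds shown alone.

Compound 3 `CC(C)(C)CCOc1cccc2ccc(N)nc12` stands second highest of the three numbers in an assay on cells with melanin-concentrating hormone receptor 1 (Homo sapiens) as the target, read by radioligand binding (a lower number here means a stronger inhibitor, a higher number a weaker inhibitor), where compound 3 gives 201 nM. Its nearest neighbour is compound 2 `Nc1ccc2cccc(OCC3CCOC3)c2n1`, which gives 115 nM, the step of a 1.7-fold higher number from compound 2 to compound 3 (0.24 log units; within the scatter) lying within the scatter. The furthest is compound 1 `CC(C)Oc1cccc2ccc(N)nc12`, which gives 437 nM, the step of a 2.2-fold lower number from compound 1 to compound 3 (0.34 log units; beyond the scatter) lying beyond it. Compound 4 `Nc1ccc2cccc(OC3CCCC3)c2n1` has not yet been measured. It differs from compound 3 by cyclopentyl in place of 3,3-dimethylbutyl on an oxygen on an aromatic ring. Among the measured compounds shown here, two measured steps bear on this change, both at the same oxygen. The step of a 2.2-fold lower number from compound 1 to compound 3 (0.34 log units; beyond the scatter) was modest and beyond the scatter, and the step of a 1.7-fold higher number from compound 2 to compound 3 (0.24 log units; within the scatter) stayed within the scatter. A cyclopentyl group shares the ring character of oxolan-3-yl and is shorter than 3,3-dimethylbutyl, so compound 4 is expected to fall near compound 3 or somewhat towards compound 1. The step of a 1.2-fold higher number from compound 3 to compound 4 (0.09 log units; within the scatter) is therefore expected to be small. The estimate for compound 4 in this assay is 250 nM, with a range from 100 nM to 600 nM.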

Compound 4, half-maximal inhibitory concentration: > 2000 nM
Compound 4 ended at the assay's limit; the forecaster's own chance of this, stated with the estimate: 2%; middle value at least 8.0-fold (0.90 log units) from the limit.
By their numbers in this assay, from the lowest: compounds 2 and 3 (each within the scatter of the next); then compound 1. At a limit, above all of these: compound 4.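

In this assay compound 4 ended at a limit and not at a number: the limit of > 2000 nM in this assay, at which 1 of the 4 values shown sits. Cyclopentyl on this oxygen gave an at least 9.9-fold higher number from compound 3 to compound 4 (0.99 log units; beyond the scatter), an at least 17-fold higher number from compound 2 to compound 4 (1.24 log units; beyond the scatter) and an at least 4.5-fold higher number from compound 1 to compound 4 (0.66 log units; beyond the scatter), so the position does not accept every carbon group, as the three earlier compounds alone might have suggested. A ring as such does not set compound 4 apart, since compound 2 also carries one and lies with compound 3 at the low end, but among these four only compound 4 has its ring bound directly to the oxygen.

From the compounds shown here alone, with a single such compound, it stays open whether that direct attachment or something else about cyclopentyl goes with the loss. A cyclopentylmethyl group, or an oxolan-3-yl group set directly on the oxygen, would separate these readings.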